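Swapping a Hydroxy for a Methyl in a Cyclic Pentapeptide

The source may report more compounds than this note shows. Statements on the series, on what has been measured and on what is new or still open speak of the compounds shown alone.

Three compounds have been measured in a functional assay on PL45 cells (Homo sapiens) for inhibition, tested at 5 uM; a lower number here means less inhibition, a higher number more inhibition at the concentration tested (going by the name of the read-out):
compound 1 `CC(C)C[C@@H]1NC(=O)[C@H](CC(C)C)NC(=O)[C@H](Cc2ccccc2)NC(=O)[C@@H](CO)NC(=O)[C@H](CC(C)C)NC1=O` gives 32%;
compound 2 `CC(C)C[C@@H]1NC(=O)[C@H](CC(C)C)NC(=O)[C@H](CC(C)C)NC(=O)[C@@H](Cc2ccc(O)cc2)NC(=O)[C@H](CC(C)C)NC1=O` gives 46%;
compound 3 `CC(C)C[C@@H]1NC(=O)[C@H](Cc2ccccc2)NC(=O)[C@H](CC(C)C)NC(=O)[C@@H](CO)NC(=O)[C@H](CC(C)C)NC1=O` gives 25%.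

Compound 3 and compound 1 lie within the usual scatter of each other in this assay, whereas compound 2 stands higher by an amount beyond the scatter. Compound 4 `CC[C@H]1NC(=O)[C@H](CC(C)C)NC(=O)[C@H](CC(C)C)NC(=O)[C@H](Cc2ccccc2)NC(=O)[C@H](CC(C)C)NC1=O` has not been measured. It differs from compound 3 in one place: methyl in place of hydroxy on a saturated chain carbon bound to a saturated ring carbon. Within the data shown here, no step between measured compounds matches this change, so no measured step guides the estimate. Compound 2, which also carries no hydroxy, gives 46%, which suggests at most a modest rise. Compound 4 is expected to show a step of a number 10 percentage points higher from compound 3 to compound 4 (within the scatter), likely near the scatter. The inhibition of compound 4 is estimated at 35%, in the range 15% to 55%.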

Compound 4, a percentage reported as inhibition, at one concentration (the size of the read-out at that concentration, not a potency): 12%
Estimate against measurement, compound 4: 23 percentage points above; the whole stated range lies above it.
By their numbers in this assay, from the lowest: compound 4; then compounds 3 and 1 (each within the scatter of the next); then compound 2.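

Moving from hydroxymethyl to ethyl on a saturated ring carbon gives, in this assay, a number 13 percentage points lower from compound 3 to compound 4 (beyond the scatter). Among these compounds, this is the first direct reading at this position, and it shows that the hydroxy cannot be exchanged for methyl here without a loss of inhibition at the concentration tested. Nothing available explains why the number falls with this change.

From the compounds shown here alone, it remains open whether an amine or a carboxylic acid at this place would keep the inhibition seen with compound 3. Also open, going by these compounds, is how a longer chain ending in hydroxy would read.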